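The source may hold more compounds than are shown below. What is called first, only, known or untested is meant among the compounds shown, and "the series" means these compounds.

The measured compounds:
Compound 1, `Cc1nc(N)c2c(-c3ccccc3)cn([C@@H]3O[C@H](CO)[C@@H](O)[C@H]3O)c2n1`, in a functional assay on CCRF-CEM cells (Homo sapiens), read by MTT assay, with a stated time of 72 h (a higher number here means a weaker inhibitor, a lower number a stronger inhibitor), gives > 20000 nM, which is a limit of the assay and not a number.
Compound 2, `O=c1[nH]cnc2c1c(-c1cc3ccccc3o1)cn2[C@@H]1O[C@H](CO)[C@@H](O)[C@H]1O`, in this assay gives > 20000 nM, likewise only a limit.
Compound 3, `Cc1nc(N)c2c(-c3cc4ccccc4o3)cn([C@@H]3O[C@H](CO)[C@@H](O)[C@H]3O)c2n1`, in this assay gives > 20000 nM, again a limit.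

From compound 3 to compound 1 the change is phenyl in place of 1-benzofuran-2-yl on an aromatic carbon. The step it made, a step that the two limits leave unreadable from compound 3 to compound 1, cannot be read, since both ends are limits. Going by the values given here, all three values rest at the limit of > 20000 nM in this assay, at which 3 of the 3 values shown sit, so no compound can be set in order against another. The core of compound 2 differs from the core of compound 3, but that difference is not broken down here.

Compound 4, `O=c1[nH]cnc2c1c(-c1ccccc1)cn2[C@@H]1O[C@H](CO)[C@@H](O)[C@H]1O`, has not been measured in this assay. From compound 2 it is reached by phenyl in place of 1-benzofuran-2-yl on an aromatic carbon, the same change at the same place as from compound 3 to compound 1. The estimated step that the limit leaves unreadable from compound 2 to compound 4 is expected to be unreadable in the same way because a step that the two limits leave unreadable from compound 3 to compound 1 was itself bounded by limits at both ends. Compound 4 is expected to give about 30000 nM, most likely reported again only as a limit, within a range of 10000 nM to 100000 nM.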

Compound 4, half-maximal inhibitory concentration: > 100000 nM
Compound 4 ended at the assay's limit; the forecaster's own chance of this, stated with the estimate: 90%; at least 3.3-fold (0.52 log units) between middle value and limit.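

Compound 2 and compound 4 both stand only at limits in this assay, which are not numbers, so no step can be read between them. The compounds shown leave open whether phenyl and 1-benzofuran-2-yl differ at all in their effect on these cells, and how the two cores compare.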